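This account rests on a few compounds, and the source may have more. Where it says the series, first, only, none or still open, it means among the compounds named here.

Within the data shown here, compound 2 `CCO/C(O)=C1\C(COCCNCC(N)=O)=NC(C)=C(C(=O)OC)C1c1ccccc1Cl` gives the lowest number of the two so far measured in a functional assay (aorta) with Rattus norvegicus as the target (on this read-out lower numbers stand for stronger inhibition and higher numbers for weaker inhibition), namely 3.98 nM; compound 1 `CCO/C(O)=C1\C(COCCN(C)/C(=N/C)NC#N)=NC(C)=C(C(=O)OC)C1c1ccccc1Cl` gives 25.1 nM, and the step of a 6.3-fold lower number from compound 1 to compound 2 (0.80 log units; beyond the scatter) lies beyond the scatter. Compound 3 `CCO/C(O)=C1\C(COCCNC(C)(C)C(N)=O)=NC(C)=C(C(=O)OC)C1c1ccccc1Cl` differs from compound 2 by 1-carbamoyl-1-methylethyl in place of carbamoylmethyl on an amine nitrogen. Among the measured compounds shown here, no measured step bears directly on this change: the one measured step swapped an entire group on the same chain, which gives no guide to adding two methyls at the carbamoyl-bearing carbon. A step near the scatter is therefore expected, a 1.6-fold higher number from compound 2 to compound 3 (0.20 log units; within the scatter). For compound 3 in this assay the estimate is 6.3 nM, spanning 2 nM to 20 nM.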

Compound 3, half-maximal inhibitory concentration: 3.16 nM
Beside the measured number, compound 3's estimate is 2.0-fold (0.30 log units) above it; the range from low to high includes it.
By their numbers in this assay, from the lowest: compounds 3 and 2 (each within the scatter of the next); then compound 1.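

In this assay the amine nitrogen carries 1-carbamoyl-1-methylethyl in place of carbamoylmethyl with no shift beyond the scatter (a 1.3-fold lower number from compound 2 to compound 3 (0.10 log units; within the scatter)). The larger group keeps the separation from the side chain of compound 1 (a 7.9-fold lower number from compound 1 to compound 3 (0.90 log units; beyond the scatter)), so this separation holds for both carbamoyl-bearing groups. Nothing available gives a reason for this reading.

Open, on these data alone, is whether the primary amide itself matters here, which a carboxylic acid or a methyl ester in its place would test. Also open, as far as these compounds go, is how a longer chain between the amine nitrogen and the carbamoyl group would read.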